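Adding a second bromo to a weak hydrazone

The source may hold more compounds than are shown below. What is called first, only, known or untested is meant among the compounds shown, and "the series" means these compounds.

The series shares a hydrazone core carrying a thiazole. In an ADME assay on HUVEC cells (Homo sapiens) for inhibition, read by MTT assay, with a stated time of 48 h (a lower number here means a stronger inhibitor, a higher number a weaker inhibitor), compound 1 `Fc1ccc(/C=N/Nc2nc(-c3ccc(C(F)(F)F)cc3)cs2)cc1F` gives 79500 nM. Compound 2 `COc1cc(/C=N/Nc2nc(-c3cccc(Br)c3)cs2)cc(Br)c1OC` reaches only the limit of this assay, > 100000 nM, so no number is known for it. On the numbers shown, compound 2 therefore stands at the limit of > 100000 nM in this assay, at which 1 of the 2 values shown sits, and its standing against compound 1 cannot be ranked beyond that. Compound 3 `COc1cc(/C=N/Nc2nc(-c3cccc(Br)c3)cs2)c(Br)c(Br)c1OC` differs from compound 2 by bromo in place of hydrogen on an aromatic carbon. Going by the values given here, no measured step of this kind is available in the set, so the change offers no guide of its own. The step from compound 2 to compound 3 is expected to be small, a step that the limit leaves unreadable from compound 2 to compound 3, and not beyond the scatter in either direction. Compound 3 is therefore estimated to give 150000 nM in this assay, in the range 40000 nM to 600000 nM, most likely again reported only as a limit.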

Compound 3, half-maximal inhibitory concentration: > 100000 nM
Compound 3 gave a limit, no number; the forecaster's own chance of this, stated with the estimate: 75%; the middle value does not contradict the limit.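

Going by these compounds alone, compound 3 gives only a limit, > 100000 nM, and compound 2 also stands at a limit, so no step between the two can be read. The compounds shown leave open whether bromo in place of hydrogen on an aromatic carbon changes anything in this assay.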